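The compounds below may be only part of what the source reports. "The series", "measured", "known", "first", "only" and "open" are said of these compounds alone.

Compound 1 `COc1cc(C(=O)Nc2nn[nH]n2)nc(-c2ccccc2OC)c1` and compound 2 `CCCCc1ccc(-c2cc(OC)cc(C(=O)Nc3nn[nH]n3)n2)cc1` share one core and were tested in a functional assay on the whole organism with Rattus norvegicus as the target, at a dose of 3 mg/kg by the oral route (a lower number here means a weaker effect, a higher number a stronger effect of the compound at the dose given), where compound 1 gives 68% and compound 2 gives 61%. The two readings lie within the usual scatter of each other, so neither is to be called stronger. Compound 3 `CNc1ccc(-c2cc(OC)cc(C(=O)Nc3nn[nH]n3)n2)cc1` differs from compound 2 by one change: methylamino in place of butyl on an aromatic carbon. Within the data shown here, no measured pair shows the effect of this change, so a modest step downward of about the size of the scatter is expected, as a number 11 percentage points lower from compound 2 to compound 3 (beyond the scatter). Compound 3 is estimated to give 50%, with a range from 20% to 75%.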

Compound 3, a percentage reported as inhibition, in the whole organism at one dose (the size of the read-out at that dose, not a potency): 79%
For compound 3 the middle estimate is 29 percentage points below the measured one; the whole stated range lies below it.
By their numbers in this assay, from the lowest: compounds 2 and 1 (each within the scatter of the next); then compound 3.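

The aromatic carbon para to a large group responds to its substituent: methylamino in place of butyl gives a number 18 percentage points higher from compound 2 to compound 3 (beyond the scatter) in this assay and so moves the reading clear of the scatter. 4-(methylamino)phenyl in place of 2-methoxyphenyl gives a number 11 percentage points higher from compound 1 to compound 3 (beyond the scatter) as well, so compound 3 stands above both earlier compounds, which the two earlier readings alone could not show. Nothing available explains this rise.

From the compounds shown here alone, whether the nitrogen or the shorter chain matters remains open. A dimethylamino group or a methyl group at this place would help separate the two.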